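This account rests on a few compounds, and the source may have more. Where it says the series, first, only, none or still open, it means among the compounds named here.

Measured compounds:
compound 1, `CC1=C(C(=O)OCc2ccccc2)C(c2ccc(-c3ccccc3C)cc2)NC(=O)N1Cc1ccc(-c2nnn[nH]2)cc1`, 73000 nM
compound 2, `CC1=C(C(=O)OCc2ccccc2)C(c2ccc(-c3ccccc3)cc2)NC(=O)N1Cc1ccc(-c2nnn[nH]2)cc1`, 96000 nM
compound 3, `CC1=C(C(=O)OCc2ccccc2)C(c2ccc(-c3ccccc3)cc2)N(Cc2ccc(-c3nnn[nH]3)cc2)C(=S)N1`, 72000 nM

All three values come from a toxicity assay on RMS13 cells (Homo sapiens) for inhibition, with a stated time of 24 h; on this read-out higher numbers stand for weaker inhibition of growth and lower numbers for stronger inhibition of growth. Compound 2 and compound 1 share a core and differ by methyl in place of hydrogen on an aromatic carbon; the step is a 1.3-fold lower number from compound 2 to compound 1 (0.12 log units; within the scatter). Compound 3 carries a different core; the difference between the two cores is not broken down here, and the values of compound 2 and compound 3 lie within the scatter of each other.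

Compound 4, `CC1=C(C(=O)OCc2ccccc2)C(c2ccc(-c3ccccc3C)cc2)N(Cc2ccc(-c3nnn[nH]3)cc2)C(=S)N1`, is not yet measured. It differs from compound 3 by methyl in place of hydrogen on an aromatic carbon, the same change as from compound 2 to compound 1. For compound 4 in this assay the step is expected to be a 1.2-fold lower number from compound 3 to compound 4 (0.08 log units; within the scatter), resting on the step of a 1.3-fold lower number from compound 2 to compound 1 (0.12 log units; within the scatter) and on compound 3 at 72000 nM. Compound 4 is therefore estimated at 60000 nM, between 35000 nM and 110000 nM.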

Compound 4, concentration for 50% growth inhibition: 62000 nM
Estimate against measurement, compound 4: 1.0-fold (0.01 log units) below; low and high end bracket the measured number.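

In this assay the change from phenyl to 2-methylphenyl gives a 1.2-fold lower number from compound 3 to compound 4 (0.06 log units; within the scatter) on the core of compound 3. The two cores show no difference in how they take this change: the same change on two cores in this assay, a 1.3-fold lower number (0.12 log units; within the scatter) from compound 2 to compound 1 and a 1.2-fold lower number (0.06 log units; within the scatter) from compound 3 to compound 4, 1.1-fold (0.05 log units) apart, within the scatter of two such steps. This supports carrying the methyl from one core to the other only as a change that stays within the scatter on both; it does not show that the methyl strengthens growth inhibition on either core, and two pairs cannot establish a general rule for the series.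

As far as these compounds go, it remains open whether a group other than methyl at this place, such as ethyl, an amine or a carboxylic acid, would move the number beyond the scatter. From the compounds shown here alone, it also remains open whether such a group would behave alike on both cores.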